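Nitro Group Added to a Fused Aromatic Ring

The source may report more compounds than this note shows. Statements on the series, on what has been measured and on what is new or still open speak of the compounds shown alone.

Compound 1, `CN(Cc1ccc(C#N)cc1)[C@@H]1CN[C@H](C(=O)N2CCSC2)C1`: 13.6 nM
Compound 2, `O=C([C@@H]1C[C@H](N2CCc3ccccc32)CN1)N1CCSC1`: 19.5 nM

In an assay on a cell-free system (plasma) for inhibition of Dipeptidyl peptidase 4 (Rattus norvegicus), read by fluorescence (a higher number here means a weaker inhibitor, a lower number a stronger inhibitor), compound 1 gives 13.6 nM and compound 2 gives 19.5 nM; the two values lie within the scatter of each other, so compound 2 stands level with compound 1 rather than apart from it. Compound 3, `O=C([C@@H]1C[C@H](N2CCc3cc([N+](=O)[O-])ccc32)CN1)N1CCSC1`, carries nitro in place of hydrogen on an aromatic carbon. Among the compounds with values here, no measured pair shows this change, so there is no step to lean on. Compound 3 is estimated at 22 nM, with a range from 6 nM to 80 nM. The step of a 1.1-fold higher number from compound 2 to compound 3 (0.05 log units; within the scatter) is expected to be small, in no direction beyond the scatter.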

Compound 3, half-maximal inhibitory concentration: 10.3 nM
Beside the measured number, compound 3's estimate is 2.1-fold (0.33 log units) above it, and the stated range covers the measured number.
By their numbers in this assay, from the lowest: compounds 3, 1 and 2 (each within the scatter of the next).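

Within the data shown here, the result gives the first reading on substitution of the fused aromatic system: in this assay, nitro in place of hydrogen on this aromatic carbon gives a 1.9-fold lower number from compound 2 to compound 3 (0.28 log units; within the scatter). The position therefore accepts a group of three heavy atoms with no step beyond the scatter. Nothing given here accounts for this reading. The compounds shown leave open how an amine or a carboxylic acid would read on this same carbon, and whether nitro on another carbon of the ring would read alike.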